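The source may report more compounds than this note shows. Statements on the series, on what has been measured and on what is new or still open speak of the compounds shown alone.

Compound 1: `O=C(Nc1cccc(-n2cc(-c3ccncc3)c(-c3ccc(Cl)c(O)c3)n2)c1)Nc1ccc(Cl)c(Cl)c1` — 1010 nM
Compound 2: `COc1cc(-c2nn(-c3cccc(NC(=O)c4ccc(Cl)c(C(F)(F)F)c4)c3)cc2-c2ccncc2)ccc1Cl` — 2400 nM

In a functional assay on A549 cells (Homo sapiens) for inhibition, read by sulforhodamine B assay, with a stated time of 48 h (on this read-out higher numbers stand for weaker inhibition of growth and lower numbers for stronger inhibition of growth), compound 2 gives 2400 nM, which is the higher of the two numbers recorded. Compound 1 gives 1010 nM in this assay, and the gap between the two lies beyond the usual scatter of this measurement, so compound 2 is the weaker inhibitor of growth among the pair.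

Compound 3 is `COc1cc(-c2nn(-c3cccc(NC(=O)Nc4cccc(C(F)(F)F)c4)c3)cc2-c2ccncc2)ccc1Cl` and has not yet been measured in this assay. It differs from compound 2 in one place: (3-(trifluoromethyl)phenyl)amino in place of 4-chloro-3-(trifluoromethyl)phenyl on a carbonyl carbon. Among the compounds with values here, no pair of measured compounds shows a change of exactly this kind, so the size of the step cannot be read off from the data at hand.

Compound 3 is therefore estimated to reach about 1500 nM in this assay, with a plausible range from 500 nM to 4500 nM. Within the data shown here, this estimate implies a step of a 1.6-fold lower number from compound 2 to compound 3 (0.20 log units; within the scatter), a modest move toward stronger inhibition of growth, chosen because compound 1, the only other compound measured, gives 1010 nM and the two numbers so far bracket the space in which compound 3 is expected to fall.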

Compound 3, concentration for 50% growth inhibition: 794 nM
Beside the measured number, compound 3's estimate is 1.9-fold (0.28 log units) above it, within the range that was stated.
By their numbers in this assay, from the lowest: compounds 3 and 1 (each within the scatter of the next); then compound 2.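

In this assay, within the data shown here, the first step that can be read at this position is a 3.0-fold lower number from compound 2 to compound 3 (0.48 log units; beyond the scatter), so the group on this carbonyl carbon does affect the read-out, and the move from compound 2 to compound 3 goes toward stronger inhibition of growth. The change has two parts, as the chlorine of 4-chloro-3-(trifluoromethyl)phenyl leaves and an amino nitrogen enters with one hydrogen-bond donor, while the trifluoromethyl-bearing phenyl ring stays, so this single step cannot divide its size between the two parts. No measurement at hand bears on why the number falls.

The compounds shown leave open which part of the change carries the step: a (4-chloro-3-(trifluoromethyl)phenyl)amino group on this carbonyl carbon, or a 3-(trifluoromethyl)phenyl group there, would separate the loss of the chlorine from the gain of the amino nitrogen. They also leave open whether a methylamino or a piperidine group, in place of the (3-(trifluoromethyl)phenyl)amino group, would keep the number of compound 3.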